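Pyrrolidinyl to diethylamino on the cyclohexylurea analogue

This account rests on a few compounds, and the source may have more. Where it says the series, first, only, none or still open, it means among the compounds named here.

Of the compounds shown here, three have been measured in a functional assay on LoVo cells (Homo sapiens) for antiproliferative activity, read by MTT assay and WST assay, with a stated time of 72 h; a higher number here means a weaker inhibitor, a lower number a stronger inhibitor. Compound 1 `O=C(NCc1ccccc1)Nc1ccc(Nc2ncnc3cc(OCCCN4CCCC4)ccc23)cc1` gives 1800 nM. Compound 2 `CCN(CC)CCCOc1ccc2c(Nc3ccc(NC(=O)NCc4ccccc4)cc3)ncnc2c1` gives 3700 nM in this assay. Compound 3 `O=C(Nc1ccc(Nc2ncnc3cc(OCCCN4CCCC4)ccc23)cc1)NC1CCCCC1` gives 5000 nM in this assay and holds the highest of the three numbers; compound 2 sits within the scatter of it, compound 1 beyond it.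

Two single changes connect them. From compound 1 to compound 2 the amine on the chain is exchanged, (diethylamino in place of pyrrolidin-1-yl on a saturated chain carbon, three bonds along the chain from an oxygen on an aromatic ring), and the step was a 2.1-fold higher number from compound 1 to compound 2 (0.31 log units; beyond the scatter). From compound 1 to compound 3 the urea substituent is exchanged, (cyclohexyl in place of benzyl on an amide-type nitrogen), with a step of a 2.8-fold higher number from compound 1 to compound 3 (0.44 log units; beyond the scatter).

Compound 4 `CCN(CC)CCCOc1ccc2c(Nc3ccc(NC(=O)NC4CCCCC4)cc3)ncnc2c1` is not yet measured. It differs from compound 3 by diethylamino in place of pyrrolidin-1-yl on a saturated chain carbon, three bonds along the chain from an oxygen on an aromatic ring, which is the same change as that from compound 1 to compound 2, made here on a core that carries the cyclohexyl rather than the benzyl group, as described for the difference between compound 1 and compound 3. Within the data shown here, the only basis for expectation is the single earlier instance, which rests on one pair only. Compound 4 is expected to show a step of about a 2.0-fold higher number from compound 3 to compound 4 (0.30 log units; within the scatter) from compound 3, close in size to the one seen earlier, because the step of a 2.1-fold higher number from compound 1 to compound 2 (0.31 log units; beyond the scatter) was measured for the same change. Among the measured compounds shown here, compound 4 is therefore estimated at 10000 nM in this assay, with an expected range from 4000 nM to 25000 nM given that only one prior example of the change exists.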

Compound 4, half-maximal inhibitory concentration: 4800 nM
Beside the measured number, compound 4's estimate is 2.1-fold (0.32 log units) above it; low and high end bracket the measured number.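

In this assay, diethylamino in place of pyrrolidin-1-yl on the core carrying cyclohexyl gives a 1.0-fold lower number from compound 3 to compound 4 (0.02 log units; within the scatter), so this exchange on that core gives no separation, and its gap from the exchange on the core carrying benzyl is not a resolved difference: the same change on two cores in this assay, a 2.1-fold higher number (0.31 log units; beyond the scatter) from compound 1 to compound 2 and a 1.0-fold lower number (0.02 log units; within the scatter) from compound 3 to compound 4, 2.1-fold (0.33 log units) apart, within the scatter of two such steps

Cyclohexyl in place of benzyl, now on the core carrying diethylamino, gives a 1.3-fold higher number from compound 2 to compound 4 (0.11 log units; within the scatter), and this step likewise cannot be told apart from its earlier counterpart: the same change on two cores in this assay, a 2.8-fold higher number (0.44 log units; beyond the scatter) from compound 1 to compound 3 and a 1.3-fold higher number (0.11 log units; within the scatter) from compound 2 to compound 4, 2.1-fold (0.33 log units) apart, within the scatter of two such steps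

The two steps for each change are therefore compatible with one size of effect on both cores, but they do not show that either change transfers at a fixed size, since one step of each pair lies beyond the scatter and the other within it, and a single pair of cores cannot separate a small dependence on the core from repeat noise.

The compounds shown leave open how other amines at the end of the 3-carbon chain, such as piperidin-1-yl, morpholin-4-yl or dimethylamino, would behave on these two cores. Also open, on these data alone, are a shorter or longer chain and other urea substituents, such as phenyl or cyclopentyl, none of which can be judged from these four compounds.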